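The compounds below may be only part of what the source reports. "The series", "measured", "known", "first", "only" and "open" are said of these compounds alone.

Compound 1 `NS(=O)(=O)c1ccc(-n2nc(-c3ccc(Cl)cc3)cc2-c2cc(O)ccc2O)cc1` gives 14700 nM in a functional assay on cells (Cancer cell lines, Homo sapiens) for cytotoxicity, read by sulforhodamine B assay, with a stated time of 48 h; on this read-out lower numbers stand for stronger inhibition of growth and higher numbers for weaker inhibition of growth. Compound 3 `NS(=O)(=O)c1ccc(-n2nc(-c3ccc(Cl)cc3)cc2C2=CC(=O)C=CC2=O)cc1` gives 26500 nM. Compound 2 `CC(=O)NS(=O)(=O)c1ccc(-n2nc(-c3ccccc3)cc2-c2cc(O)ccc2O)cc1` gives 100000 nM, the highest of the three numbers.

Compound 4 `CC(=O)NS(=O)(=O)c1ccc(-n2nc(-c3ccccc3)cc2C2=CC(=O)C=CC2=O)cc1` has not been measured. Relative to compound 2 it carries the change (a group of 8 heavy atoms (6 carbon, 2 oxygen; one six-membered non-aromatic ring of carbon only) in place of a group of 8 heavy atoms (6 carbon, 2 oxygen; one six-membered aromatic ring of carbon only), on an aromatic carbon). The same kind of change was made from compound 1 to compound 3, namely (a group of 8 heavy atoms (6 carbon, 2 oxygen; one six-membered non-aromatic ring of carbon only) in place of a group of 8 heavy atoms (6 carbon, 2 oxygen; one six-membered aromatic ring of carbon only), on an aromatic carbon), and there it produced a 1.8-fold higher number from compound 1 to compound 3 (0.26 log units; within the scatter). The surroundings differ: in compound 1 the place sits next to the ring atom that bears a 4-sulfamoylphenyl group and two ring bonds from the ring atom that bears a 4-chlorophenyl group, while in compound 2 it sits next to the ring atom that bears a large group and two ring bonds from the ring atom that bears a phenyl group. The difference between the cores of compound 1 and compound 2 is not broken down here. The expectation rests on compound 1 and compound 3, whose step was a 1.8-fold higher number from compound 1 to compound 3 (0.26 log units; within the scatter), and on compound 2 already giving 100000 nM. A step of no change at the digits printed from compound 2 to compound 4 (within the scatter) is therefore expected. Compound 4 is estimated at 100000 nM, likely between 45000 nM and 220000 nM.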

Compound 4, concentration for 50% growth inhibition: 100000 nM
For compound 4 middle estimate and measured number coincide at the digits printed; the measured number falls inside the stated range.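

In this assay, putting the non-aromatic six-membered carbon ring in place of the 2,5-dihydroxyphenyl group gives no change at the digits printed from compound 2 to compound 4 (within the scatter). Set beside the earlier case, the change behaves alike on both cores: the same change on two cores in this assay, a 1.8-fold higher number (0.26 log units; within the scatter) from compound 1 to compound 3 and no change at the digits printed (within the scatter) from compound 2 to compound 4, 1.8-fold (0.26 log units) apart, within the scatter of two such steps This shows only that the swap leaves the number within the scatter on these two cores; two pairs cannot establish a rule for other cores, and they do not explain why the number holds.

Still open, from the compounds shown here alone, is whether an amine or a carboxylic acid at this place on the five-membered ring would move the number. Also open, going by these compounds, are the separate contributions of the acetyl group on the sulfonamide and the chlorine on the phenyl ring.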